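The source may report more compounds than this note shows. Statements on the series, on what has been measured and on what is new or still open speak of the compounds shown alone.

Compound 1, `CCN(CC)C(=O)c1nc2ccccc2n1Cc1ccccc1`, gives in an assay on HEK293 cells for displacement of a labelled ligand from Translocator protein (Homo sapiens), read by scintillation counting, with a stated time of 90 min (a lower number here means a stronger inhibitor, a higher number a weaker inhibitor), only the limit > 10000 nM. Compound 2, `CCN(CC)C(=O)c1nc2ccccc2n1Cc1ccc(Cl)cc1`, gives in this assay 2570 nM.

Compound 2 therefore holds the only number shown in this assay; the other value is a limit (the limit of > 10000 nM in this assay, at which 1 of the 2 values shown sits). For the measured compounds named here, the one measured step, an at least 3.8-fold lower number from compound 1 to compound 2 (0.59 log units; beyond the scatter), is chloro in place of hydrogen on an aromatic carbon, and it shows that the group on the benzylic ring is the part of the molecule that moved the number.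

Compound 3, `CCN(CC)C(=O)c1nc2ccccc2n1Cc1ccc(OC)nc1`, differs from compound 2 by 6-methoxypyridin-3-yl in place of 4-chlorophenyl on a saturated chain carbon bound to an aromatic nitrogen. This removes the chloro that the measured step rewarded and also swaps the ring, so the step bears on it only indirectly. The expectation is a modest rise in the number, a 2.3-fold higher number from compound 2 to compound 3 (0.37 log units; beyond the scatter). Compound 3 is thus estimated at 6000 nM, with a range from 2000 nM to 20000 nM.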

Compound 3, inhibition constant: > 10000 nM
Compound 3 ended at the assay's limit (the forecaster's own chance of this, stated with the estimate: 35%); middle value at least 1.6-fold (0.22 log units) from the limit.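

In this assay, putting 6-methoxypyridin-3-yl in place of 4-chlorophenyl on the saturated chain carbon gives an at least 3.8-fold higher number from compound 2 to compound 3 (0.59 log units; beyond the scatter). A group on the ring is therefore not enough by itself: among the compounds shown, only the 4-chlorophenyl ring gives a number, while the methoxy-bearing pyridine ring of compound 3 does not. The step between compound 1 and compound 3 cannot be read, because each of the two compounds ends at a limit: the limit of > 10000 nM in this assay, at which 2 of the 3 values shown sit.

The change brings in a ring nitrogen and a methoxy group together, and the compounds shown do not tell which of the two accounts for the step. A 4-methoxyphenyl or 6-chloropyridin-3-yl ring would separate them, and a 4-bromophenyl ring would show whether another halogen can take the place of chloro.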